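This account rests on a few compounds, and the source may have more. Where it says the series, first, only, none or still open, it means among the compounds named here.

Compound 3 `COc1ccc(-n2nc(Sc3ccc(Cl)cc3)cc(CC[C@@H](C)NC(=O)[C@H]3CNCC[C@@H]3c3ccc4ccccc4c3)c2=O)cc1` stands second highest of the three numbers in an assay on CHO cells for binding affinity to Melanocortin receptor 4 (Homo sapiens); on this read-out higher numbers stand for weaker inhibition and lower numbers for stronger inhibition: compound 3 gives 17 nM, compound 1 `COc1ccc(-n2nc(Sc3ccc(Cl)cc3)cc(CC[C@@H](C)NC(=O)[C@H]3CNCC[C@@H]3c3cccc(Cl)c3)c2=O)cc1` gives 43 nM, and compound 2 `COc1ccc(-n2nc(Sc3ccc(Cl)cc3)cc(CC[C@@H](C)NC(=O)[C@H]3CNCC[C@@H]3c3ccc(C(F)(F)F)cc3)c2=O)cc1` gives 3.8 nM. Compound 4 `COc1ccc(-n2nc(Sc3ccc(Cl)cc3)cc(CC[C@@H](C)NC(=O)[C@H]3CNCC[C@@H]3c3cccc4ccccc34)c2=O)cc1` differs from compound 3 by naphthalen-1-yl in place of naphthalen-2-yl on a saturated ring carbon. Going by the values given here, no measured step swaps one attachment point of the same ring system for another; the steps that bear on the group on that saturated ring carbon are an 11-fold lower number from compound 1 to compound 2 (1.05 log units; beyond the scatter), a 2.5-fold lower number from compound 1 to compound 3 (0.40 log units; beyond the scatter) and a 4.5-fold higher number from compound 2 to compound 3 (0.65 log units; beyond the scatter), so exchanging this group has moved this assay by modest to large amounts. For a swap that keeps the same ring system, only a small change is expected, with the direction uncertain, as a 1.5-fold higher number from compound 3 to compound 4 (0.17 log units; within the scatter). Compound 4 is therefore estimated at 25 nM, within 8 nM to 80 nM.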

Compound 4, half-maximal inhibitory concentration: 89 nM
The estimate for compound 4 lay 3.6-fold (0.55 log units) below the measured number, outside the stated range (above it).
By their numbers in this assay, from the lowest: compound 2; then compound 3; then compound 1; then compound 4.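

Simply moving the attachment from naphthalen-2-yl to naphthalen-1-yl, with the same atoms, gives a 5.2-fold higher number from compound 3 to compound 4 (0.72 log units; beyond the scatter) in this assay, so the attachment point matters here and not only the choice of group. Naphthalen-1-yl is also the weakest of the four groups, with a 2.1-fold higher number from compound 1 to compound 4 (0.32 log units; beyond the scatter) and a 23-fold higher number from compound 2 to compound 4 (1.37 log units; beyond the scatter) on the same read-out. No evidence is available to explain this difference.

Going by these compounds, it remains open whether attachment point matters equally for single rings, as 4-chlorophenyl or 3-(trifluoromethyl)phenyl would show. Either group would also separate the effect of position from that of chlorine versus trifluoromethyl.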